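Methyl in Place of Chloro: Solubility Outlook for Compound 4

The source may hold more compounds than are shown below. What is called first, only, known or untested is meant among the compounds shown, and "the series" means these compounds.

compound 1 `CC(C)Nc1nc(NCc2ccco2)c2cccc(Cl)c2n1` — in a physicochemical assay for solubility, at pH 2 (a lower number here means a less soluble compound, a higher number a more soluble compound), compound 1 gives >= 30000 nM, a limit of the assay
compound 2 `CC(C)Nc1nc(NCc2ccco2)c2c(Cl)cccc2n1` — in this assay compound 2 gives >= 30000 nM, a limit of the assay
compound 3 `Cc1cccc2c(NCc3ccco3)nc(NC(C)C)nc12` — in this assay compound 3 gives >= 30000 nM, a limit of the assay

Compounds 1 and 2 are built from the same atoms joined differently; the difference between their two cores is not broken down here. Compound 3 differs from compound 1 by methyl in place of chloro on an aromatic carbon, and the step that the two limits leave unreadable from compound 1 to compound 3 cannot be sized because of the limit of >= 30000 nM in this assay, at which 3 of the 3 values shown sit. Compound 2 likewise stands only at a limit in this assay.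

Compound 4 `Cc1cccc2nc(NC(C)C)nc(NCc3ccco3)c12` is not yet measured. It differs from compound 2 by methyl in place of chloro on an aromatic carbon, the same change that carries compound 1 to compound 3. Since compound 2 itself sits at the limit, the step of a number no higher from compound 2 to compound 4 (the limit leaves the size open) is expected to be unreadable in the same way. Compound 4 is therefore estimated at 30000 nM, within 15000 nM to 60000 nM, most likely reported again as a limit.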

Compound 4, solubility: >= 30000 nM
Compound 4: only a limit was reported; the forecaster's own chance of this, stated with the estimate: 85%; the middle value sits exactly at the limit.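

In this assay compound 4 gives >= 30000 nM, which is a limit of the assay. No new step can be read between compound 2 and compound 4, as both stand only at a limit: the limit of >= 30000 nM in this assay, at which 4 of the 4 values shown sit.

The compounds shown leave open how their values compare in this assay, and what size, if any, the change of methyl in place of chloro on an aromatic carbon has there.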